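The source may hold more compounds than are shown below. What is called first, only, known or untested is meant among the compounds shown, and "the series" means these compounds.

Compound 1 `O=C(/C=C/c1ccc2c(c1)B(O)OC2)c1ccc(F)cc1` and compound 2 `O=C(/C=C/c1ccc2c(c1)B(O)OC2)c1ccc(OCc2ccccc2)cc1` share one core and differ only in the group on the carbonyl carbon. In a toxicity assay on MCF-10A cells (Homo sapiens) for cytotoxicity, read by MTT assay, with a stated time of 48 h (a lower number here means a stronger inhibitor, a higher number a weaker inhibitor), compound 1 gives 11800 nM, the lowest of the two numbers. Compound 2 gives 23300 nM, and a 2.0-fold higher number from compound 1 to compound 2 (0.30 log units; within the scatter). Compound 3 `O=C(/C=C/c1ccc2c(c1)B(O)OC2)c1ccccc1O` is compound 1 with 2-hydroxyphenyl in place of 4-fluorophenyl on a carbonyl carbon. Among the measured compounds shown here, only that one measured step, itself within the scatter, bears on this change, so no step beyond the scatter is expected in this assay in either direction. Compound 3 is therefore estimated at 12000 nM, with a range from 5000 nM to 30000 nM. The step this estimate means, a 1.0-fold higher number from compound 1 to compound 3 (0.01 log units; within the scatter), is expected to stay within the scatter.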

Compound 3, half-maximal inhibitory concentration: 53700 nM
Beside the measured number, compound 3's estimate is 4.5-fold (0.65 log units) below it, and the stated range ends below it.
By their numbers in this assay, from the lowest: compounds 1 and 2 (each within the scatter of the next); then compound 3.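

In this assay, among the compounds shown here, the change to 2-hydroxyphenyl in place of 4-fluorophenyl on a carbonyl carbon brings a 4.6-fold higher number from compound 1 to compound 3 (0.66 log units; beyond the scatter) and so gives the first step here that lies beyond the scatter, though a modest one. The number thus responds to the group at this place, which the earlier step of a 2.0-fold higher number from compound 1 to compound 2 (0.30 log units; within the scatter) could not show. No measurement at hand accounts for this step.

On these data alone, whether a 4-hydroxyphenyl or a 2-methoxyphenyl group on this carbonyl carbon would give a number like that of compound 1 or that of compound 3 stays open.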